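The source may report more compounds than this note shows. Statements on the series, on what has been measured and on what is new or still open speak of the compounds shown alone.

Measured so far in a functional assay on CHO-RD-HGA16 cells for agonist activity at Orexin receptor type 2 (Homo sapiens), read by fluorescence and calcium flux, with a stated time of 30 min; a lower number here means that less compound is needed, a higher number that more compound is needed for the effect:
- compound 1 `COc1ccc(-c2cccc(C(=O)N(C)C)c2)cc1S(=O)(=O)Nc1cccc(N2CCN(C(=O)c3cccc(C)c3)CC2)c1`: compound 1 gives > 10000 nM, a limit of the assay rather than a number.
- compound 2 `COc1ccc(-c2cccc(C(=O)N(C)CCN(C)C)c2)cc1S(=O)(=O)Nc1cccc(NCCNC(=O)c2cccc(C)c2)c1`: compound 2 gives 293 nM.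
- compound 3 `COc1ccc(-c2cccc(C(=O)NCCN(C)C)c2)cc1S(=O)(=O)Nc1cccc(NCCNC(=O)c2cccc(C)c2)c1`: compound 3 gives 1630 nM.

Compound 3 stands highest of the two numbers; its nearest neighbour is compound 2, and the step of a 5.6-fold higher number from compound 2 to compound 3 (0.75 log units; beyond the scatter) separates them. Compound 4 `COc1ccc(-c2cccc(C(=O)N(C)Cc3ccccc3)c2)cc1S(=O)(=O)Nc1cccc(NCCNC(=O)c2cccc(C)c2)c1` carries the change (benzyl(methyl)amino in place of (2-(dimethylamino)ethyl)amino on a carbonyl carbon). It restores a methyl on the amide-type nitrogen, the reverse of what the step from compound 2 to compound 3 removed, but at the same time trades the (2-(dimethylamino)ethyl) chain for a benzyl. Among the compounds with values here, no measured step covers that second part. The expected step of a 2.7-fold lower number from compound 3 to compound 4 (0.43 log units; beyond the scatter) is therefore modest and downward, landing compound 4 near the value of compound 2, with wide uncertainty. Compound 4 is estimated at 600 nM, range 150 nM to 3000 nM.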

Compound 4, half-maximal effective concentration: 532 nM
Compound 4: middle estimate off by 1.1-fold (0.05 log units), on the high side; the range from low to high includes it.
By their numbers in this assay, from the lowest: compounds 2 and 4 (each within the scatter of the next); then compound 3. At a limit, above all of these: compound 1.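

Benzyl(methyl)amino in place of (2-(dimethylamino)ethyl)amino on a carbonyl carbon gives a 3.1-fold lower number from compound 3 to compound 4 (0.49 log units; beyond the scatter) in this series. Phenyl in place of (dimethylamino)methyl on a saturated chain carbon bound to an amide-type nitrogen gives a 1.8-fold higher number from compound 2 to compound 4 (0.26 log units; within the scatter) so, among these compounds, a terminal dimethylamino group is not needed for a number in this range. No measurement shown gives a reason for either step.

Still open, on these data alone, is how far the methyl and the phenyl each contribute, which a benzylamino group would separate. A carboxylic acid or a longer chain on the same carbonyl carbon also remains to be read.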